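Alkyl chain steps on the aromatic nitrogen

The compounds below may be only part of what the source reports. "The series", "measured", "known", "first", "only" and "open" are said of these compounds alone.

Measured in a functional assay on PC-3 cells (Homo sapiens) for cytotoxicity, read by WST assay, with a stated time of 3 days; a lower number here means a stronger inhibitor, a higher number a weaker inhibitor:
- compound 1 `CCCCCn1ccnc1/C=C/C(=O)/C=C/c1coc2ccccc2c1=O`: 2100 nM
- compound 2 `CC(C)n1ccnc1/C=C/C(=O)/C=C/c1coc2ccccc2c1=O`: 2300 nM
- compound 3 `CCC(C)n1ccnc1/C=C/C(=O)/C=C/c1coc2ccccc2c1=O`: 1800 nM

Compound 3 gives 1800 nM, within the scatter of both compound 1 and compound 2. Compound 4 `CCCC(C)n1ccnc1/C=C/C(=O)/C=C/c1coc2ccccc2c1=O` carries one further change, (methyl in place of hydrogen on a saturated chain carbon, three bonds along the chain from an aromatic nitrogen), which turns sec-butyl into 1-methylbutyl. The closest measured change is also a methyl in place of hydrogen, a 1.3-fold lower number from compound 2 to compound 3 (0.11 log units; within the scatter). The exchange of chains gave a 1.1-fold higher number from compound 1 to compound 2 (0.04 log units; within the scatter) and a 1.2-fold lower number from compound 1 to compound 3 (0.07 log units; within the scatter). All three steps stay within the scatter, so no step beyond the scatter is expected in this assay. The expected step is a 1.1-fold higher number from compound 3 to compound 4 (0.02 log units; within the scatter). For compound 4 the estimated value is 1900 nM, with an expected range of 1000 nM to 3500 nM.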

Compound 4, half-maximal inhibitory concentration: 3200 nM
The estimate for compound 4 lay 1.7-fold (0.23 log units) below the measured number; measured number inside the range.
By their numbers in this assay, from the lowest: compounds 3, 1, 2 and 4 (each within the scatter of the next).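

Lengthening sec-butyl to 1-methylbutyl in this assay gives the largest step at this position so far (a 1.8-fold higher number from compound 3 to compound 4 (0.25 log units; within the scatter)), yet it stays within the scatter. The steps to compound 4 from the other two chains (a 1.4-fold higher number from compound 2 to compound 4 (0.14 log units; within the scatter)) and (a 1.5-fold higher number from compound 1 to compound 4 (0.18 log units; within the scatter)) are also within the scatter, so this read-out does not separate isopropyl, sec-butyl, pentyl and 1-methylbutyl on the aromatic nitrogen. Nothing available explains any of these small differences.

Going by these compounds, whether an amine or a carboxylic acid in place of these alkyl chains, or a chain longer than pentyl, would move the number beyond the scatter stays open.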